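The source may hold more compounds than are shown below. What is called first, only, known or untested is meant among the compounds shown, and "the series" means these compounds.

Three compounds share one core and differ only in the group attached to a saturated chain carbon bound to an aromatic nitrogen. Compound 1 `O=C(O)CNC(=O)c1c(O)c2c(n(Cc3ccc(Cl)cc3)c1=O)COC2` gives 2.5 10^-6 cm/s in an ADME assay on LLC-PK1 cells (Sus scrofa) for permeability, with a stated time of 3 h, tested at 1 uM; a lower number here means that the compound crosses the layer more slowly, a higher number that the compound crosses the layer faster. In this assay compound 2 `O=C(O)CNC(=O)c1c(O)c2c(n(Cc3cc(F)c(F)cc3F)c1=O)COC2` gives "not determined" (no result reported), so compound 2 stands without a value of its own. Compound 3 `O=C(O)CNC(=O)c1c(O)c2c(n(Cc3cnc(C(F)(F)F)s3)c1=O)COC2` carries 2-(trifluoromethyl)-1,3-thiazol-5-yl in place of 2,4,5-trifluorophenyl on a saturated chain carbon bound to an aromatic nitrogen. Going by the values given here, with no measured step to rest on, any difference between compound 2 and compound 3 in this assay is expected to stay within the usual scatter. For compound 3 the apparent permeability is estimated at 2 10^-6 cm/s, within a range from 0.7 10^-6 cm/s to 6 10^-6 cm/s.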

Compound 3, apparent permeability: < 1.5 10^-6 cm/s
Compound 3 gave a limit, no number; the forecaster's own chance of this, stated with the estimate: 10%; middle value at least 1.3-fold (0.12 log units) from the limit.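

Compound 3 gives only a limit of the assay in this assay, not a number: the limit of < 1.5 10^-6 cm/s in this assay, at which 1 of the 3 values shown sits. Placing 2-(trifluoromethyl)-1,3-thiazol-5-yl instead of 4-chlorophenyl on a saturated chain carbon bound to an aromatic nitrogen gives an at least 1.6-fold lower number from compound 1 to compound 3 (0.22 log units; that floor lies within the scatter), so the first readable step at this position does not yet establish a change beyond the scatter. The step from compound 2 cannot be read.

On these data alone, how far the true value of compound 3 lies from that limit remains open. So does the effect on apparent permeability of an amine or a carboxylic acid at this position.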